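The compounds below may be only part of what the source reports. "The series", "measured", "known", "first", "only" and "open" are said of these compounds alone.

Working notes on the quinolinylmethoxy series in an assay on isolated protein for binding affinity to cysteinyl leukotriene receptor 1 (Cavia porcellus); on this read-out higher numbers stand for weaker inhibition and lower numbers for stronger inhibition.

Among the compounds with values here, compound 1 `c1cc(OCc2ccc3ccccc3n2)cc(OCc2nn[nH]n2)c1` gives 85 nM and compound 3 `c1cc(OCCCCc2nnn[nH]2)cc(OCc2ccc3ccccc3n2)c1` gives 75 nM; the one step between them, a 1.1-fold lower number from compound 1 to compound 3 (0.05 log units; within the scatter), shows that stretching the tetrazole away from the ring changes nothing measurable. Compound 2 `c1ccc2nc(COc3ccc(CCc4nnn[nH]4)cc3)ccc2c1` gives 160 nM. Its number sits above that of compound 3 by a gap beyond the scatter, whereas the gap to compound 1 lies within the scatter, so compound 2 cannot be called weaker than compound 1 on this evidence.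

Compound 4 `O=C(O)CCCOc1ccc(OCc2ccc3ccccc3n2)cc1` is not yet measured. Against compound 2 the change is 3-carboxypropoxy in place of 2-(1H-tetrazol-5-yl)ethyl on an aromatic carbon. Of the measured steps only a 1.1-fold lower number from compound 1 to compound 3 (0.05 log units; within the scatter) touches the same part of the molecule, and it concerns chain length alone, not the exchange of the tetrazole for a carboxylic acid. Within the data shown here, no measured pair in this set swaps one acidic head for the other, so the size of that exchange is unknown here. Given the flat chain-length step, the expected step of a 1.9-fold higher number from compound 2 to compound 4 (0.27 log units; within the scatter) is set as a modest rise in the number with wide uncertainty. Compound 4 is therefore estimated at 300 nM, with a range from 100 nM to 900 nM.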

Compound 4, inhibition constant: 1200 nM
The estimate for compound 4 lay 4.0-fold (0.60 log units) below the measured number; the whole stated range lies below it.
By their numbers in this assay, from the lowest: compounds 3, 1 and 2 (each within the scatter of the next, the first and the last beyond it); then compound 4.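

In this assay, putting 3-carboxypropoxy in place of 2-(1H-tetrazol-5-yl)ethyl on an aromatic carbon para to a large group gives a 7.5-fold higher number from compound 2 to compound 4 (0.88 log units; beyond the scatter), so this exchange clearly registers on the read-out. The earlier step, a 1.1-fold lower number from compound 1 to compound 3 (0.05 log units; within the scatter), stayed within the scatter, so the flat result for a change of tetrazole-bearing chain does not extend to this exchange, in which the five-membered aromatic ring gives way to an open chain with no ring, although both groups hold 7 heavy atoms. Nothing available here accounts for the size of this step.

The step changes the end group and the link to the aromatic carbon together, so the compounds shown leave open which of the two carries the rise in the number. A 3-carboxypropyl group or a 3-(1H-tetrazol-5-yl)propoxy group on the same aromatic carbon would separate the two changes, and a longer chain ending in a carboxylic acid would show whether chain length matters for that end group at this position.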